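The source may hold more compounds than are shown below. What is called first, only, known or untested is meant among the compounds shown, and "the series" means these compounds.

Working notes on the series. Among the compounds with values here, compound 3 `C#CCc1c(Cl)cc(N/C=N/OCOCC)cc1Cl` gives the lowest of the three numbers so far in a physicochemical assay for lipophilicity, measured as octanol-water partition; a higher number here means a more lipophilic compound, a lower number a more polar compound: compound 3 gives 3.5, while compound 1 `C#CCc1c(Cl)cc(N/C=N/OCCC)cc1Cl` gives 4 and compound 2 `C#CCc1c(Cl)cc(N/C=N/OCCCC)cc1Cl` gives 4.4. The steps of a number 0.50 log units lower from compound 1 to compound 3 (beyond the scatter) and a number 0.90 log units lower from compound 2 to compound 3 (beyond the scatter) both lie beyond the scatter, as does a number 0.40 log units higher from compound 1 to compound 2 (beyond the scatter).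

Compound 4 `C#CCc1c(Cl)cc(N/C=N/Oc2ccccc2)cc1Cl` differs from compound 3 as follows.
phenyl in place of ethoxymethyl on an oxygen

Within the data shown here, no measured step puts a ring on this oxygen, so the guide is indirect: compound 3, with its ethoxymethyl, sits below both all-carbon chains by a number 0.50 log units lower from compound 1 to compound 3 (beyond the scatter) and a number 0.90 log units lower from compound 2 to compound 3 (beyond the scatter). Phenyl in place of ethoxymethyl is therefore expected to move compound 4 upward by roughly a number 0.90 log units higher from compound 3 to compound 4 (beyond the scatter). The estimate for compound 4 is 4.4, within 3.9 to 4.9.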

Compound 4, partition coefficient: 4.4
Compound 4: middle estimate and measured number agree at the digits printed; measured number inside the range.
By their numbers in this assay, from the lowest: compound 3; then compound 1; then compounds 2 and 4 (each within the scatter of the next).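

Within the data shown here, on this oxygen a ring now stands for the first time: in this assay phenyl reads level with butyl at no change at the digits printed from compound 2 to compound 4 (within the scatter) and sits clear of propyl at a number 0.40 log units higher from compound 1 to compound 4 (beyond the scatter) and of ethoxymethyl at a number 0.90 log units higher from compound 3 to compound 4 (beyond the scatter). At this oxygen, this read-out does not tell a six-membered aromatic ring of carbon only from the open butyl chain. No evidence accompanies these numbers to account for them. From the compounds shown here alone, whether a pyridyl ring or a benzyl group on the same oxygen would read like phenyl stays open, as does the reading for a chain ending in an amine or a carboxylic acid.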